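The compounds below may be only part of what the source reports. "The series", "measured", "known", "first", "only" and "open" are said of these compounds alone.

Of the compounds shown here, three of one series have been tested in an ADME assay on PBMC cells (Homo sapiens) for cytotoxicity; on this read-out lower numbers stand for higher toxicity in this test and higher numbers for lower toxicity in this test. Compound 1 `CC(CCNC(=O)c1c(Cl)cncc1Cl)N1CCC(C(Oc2cccc(Cl)n2)c2ccc(OC(F)(F)F)cc2)CC1` gives 6000 nM in this assay, the lowest of the three numbers. Compound 2 `CC(CCNC(=O)c1c(Cl)cncc1Cl)N1CCC(C(Oc2ccccn2)c2ccc(Br)cc2)CC1` gives 33700 nM, a higher number that lies beyond the scatter of the test. Compound 3 `CC(CCNC(=O)c1c(Cl)cncc1Cl)N1CCC(C(=O)c2ccc(Br)cc2)CC1` gives 189000 nM, the highest of the three and furthest from compound 1. Compound 1 thus stands at the toxic end of what has been measured so far, with both companions clearly above it.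

Compound 4 `CC(CCNC(=O)c1c(Cl)cncc1Cl)N1CCC(C(Oc2cccc(Cl)n2)c2ccc(C(F)(F)F)cc2)CC1` has not yet been measured. Compared with compound 1 the change is trifluoromethyl in place of trifluoromethoxy on an aromatic carbon. Within the data shown here, no pair among the measured compounds shows this kind of change, so no measured step can be pointed to as a guide; the two measured neighbours of compound 1 differ from it in other places altogether.

For compound 4 the expected step is no change at the digits printed from compound 1 to compound 4 (within the scatter), that is, no move beyond the scatter of repeated measurements in either direction. Compound 4 is therefore estimated to give 6000 nM in this assay, with a plausible range from 2500 nM to 15000 nM.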

Compound 4, half-maximal cytotoxic concentration: > 32500 nM
Compound 4 gave a limit, no number; the forecaster's own chance of this, stated with the estimate: 5%; at least 5.4-fold (0.73 log units) between middle value and limit.
By their numbers in this assay, from the lowest: compound 1; then compound 2; then compound 3.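

The entry for compound 4 is a limit of the assay and not a number: the limit of > 32500 nM in this assay, at which 1 of the 4 values shown sits. Trifluoromethyl in place of trifluoromethoxy, on an aromatic carbon para to a large group, gives an at least 5.4-fold higher number from compound 1 to compound 4 (0.73 log units; beyond the scatter) in this assay and this is the first step in the series that changes one place only. Among these compounds, a change of a single oxygen atom at this position, with the rest of compound 1 held constant, is therefore enough to move the read-out away from the toxic end of the series, which the earlier compounds could not show, as each of them differs from compound 1 in more than one place.

The compounds shown fix only a lower bound for the size of this step and give no reason why this small change matters so much. They also do not tell whether this position would respond in the same way to a methoxy group, a nitrile or an amine, or whether the same change would have a similar effect in a compound carrying the other groups of compound 2.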